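Swapping the Aryl Group: Expected Solubility of Compound 3

The source may hold more compounds than are shown below. What is called first, only, known or untested is meant among the compounds shown, and "the series" means these compounds.

Among the compounds with values here, compound 2 `Cc1cc(NCc2ccccn2)n2ncc(-c3cccc(F)c3)c2n1` is the one compound here with a plain number to its name: in a physicochemical assay for solubility, read by HPLC, using the shake flask method, measured as kinetic solubility, with a stated time of 2 h, at pH 7.4 (a higher number here means a more soluble compound, a lower number a less soluble compound), compound 2 gives 5000 nM. Compound 1 `Cc1ccc(-c2cnn3c(NCc4ccccn4)cc(C)nc23)cc1` differs from compound 2 only in the aryl group on the core, and in this assay compound 1 gives < 5000 nM, which is a limit of the assay and not a number. The step between them is therefore a number no lower from compound 1 to compound 2 (the limit leaves the size open), and its size cannot be read; the limit of < 5000 nM in this assay, at which 1 of the 2 values shown sits, is simply where compound 1 sits.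

Compound 3 `Cc1cc(NCc2ccccn2)n2ncc(-c3ccccc3C)c2n1` is not yet measured. It differs from compound 2 by 2-methylphenyl in place of 3-fluorophenyl on an aromatic carbon. Within the data shown here, the single measured step concerns the same position and the same kind of group, a substituted phenyl ring, but its size is hidden by the limit, so it offers a direction at best and no magnitude. The expectation for compound 3 is therefore a step of a 1.3-fold lower number from compound 2 to compound 3 (0.10 log units; within the scatter), with no change beyond the scatter expected. Compound 3 is estimated to give 4000 nM in this assay, within 1500 nM and 12000 nM, and a reading at the limit cannot be ruled out.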

Compound 3, solubility: < 5000 nM
Compound 3: only a limit was reported (the forecaster's own chance of this, stated with the estimate: 50%); the middle value is on the limit's open side.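

With 2-methylphenyl in place of 3-fluorophenyl on the shared core, this assay shows a number no higher from compound 2 to compound 3 (the limit leaves the size open). The result for compound 3 is a limit and not a number, so the step from compound 1 to compound 3 cannot be read either, and neither step has a size. Among the three compounds, both methylphenyl groups, 4-methylphenyl in compound 1 and 2-methylphenyl in compound 3, now end at a limit, while only the 3-fluorophenyl group of compound 2 gives a plain number, and so the limit has become the usual reading for this small set: the limit of < 5000 nM in this assay, at which 2 of the 3 values shown sit.

On these data alone, how far compound 1 and compound 3 actually lie from compound 2 stays open, as does whether the difference follows the methyl group, the fluorine or the place each occupies on the phenyl ring. Also open, as far as these compounds go, is what a phenyl ring carrying an amine or a carboxylic acid would give at this carbon of the five-membered aromatic ring.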